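Swapping a nitrophenyl for a dichlorophenyl on an amide nitrogen

The source may report more compounds than this note shows. Statements on the series, on what has been measured and on what is new or still open speak of the compounds shown alone.

Measured so far:
- compound 1 `CO[C@@H]1CC=C2NN(c3ccc([N+](=O)[O-])cc3)C(=O)CC[C@]2(c2ccccc2)O1`: 9490 nM
- compound 2 `CO[C@@H]1CC=C2N(c3ccc([N+](=O)[O-])cc3)C(=O)C[C@]2(c2ccccc2)O1`: 7150 nM

Of the compounds shown here, two sharing a core have been tested in a functional assay on A549 cells (Homo sapiens) for cytotoxicity, read by sulforhodamine B assay, with a stated time of 48 h; on this read-out higher numbers stand for weaker inhibition and lower numbers for stronger inhibition. Compound 1 gives 9490 nM, and compound 2 gives 7150 nM. Compound 2 has the lower of the two numbers, but its gap to compound 1 lies within the usual scatter of repeated measurements, so the two cannot be told apart on these data.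

Compound 3 `CO[C@@H]1CC=C2N(c3cc(Cl)cc(Cl)c3)C(=O)C[C@]2(c2ccccc2)O1` is the next step from compound 2. The change is 3,5-dichlorophenyl in place of 4-nitrophenyl on an amide-type nitrogen in a ring. Among the measured compounds shown here, nothing measured so far shows what this swap does, so the expectation rests on the shared core alone: compound 2 is a modest hit in this assay, and a change on its aryl group is expected to move the number little. For compound 3 a step of a 1.2-fold lower number from compound 2 to compound 3 (0.08 log units; within the scatter) is expected, which lies within the scatter. The estimate for compound 3 in this assay is 6000 nM, with a range from 2000 nM to 20000 nM.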

Compound 3, half-maximal inhibitory concentration: 7530 nM
The estimate for compound 3 lay 1.3-fold (0.10 log units) below the measured number; the range from low to high includes it.
By their numbers in this assay, from the lowest: compounds 2, 3 and 1 (each within the scatter of the next).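

In this assay, putting 3,5-dichlorophenyl in place of 4-nitrophenyl on the amide-type nitrogen in the ring gives a 1.1-fold higher number from compound 2 to compound 3 (0.02 log units; within the scatter), so compound 2 and compound 3 cannot be told apart. Among the compounds shown here, this is the first reading of a change at this position, and it shows that a group with hydrogen-bond acceptors can give way to one with none, and a nitro group to two chlorines, without a measurable shift in this read-out. No measurement at hand explains this result.

From the compounds shown here alone, whether an amine or a carboxylic acid on this phenyl ring, or a longer alkyl chain in its place, would move the number beyond the scatter stays open. It also remains unclear whether any group on this nitrogen can separate itself from these two in this read-out.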